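This account rests on a few compounds, and the source may have more. Where it says the series, first, only, none or still open, it means among the compounds named here.

Compound 1 `C=C1c2c(C)nc(OC)c(C#N)c2N=CN1Cc1ccccc1` and compound 2 `C=C1c2c(C)nc(OC)c(C#N)c2N=CN1Cc1ccc(Cl)cc1` share one core and differ only in the substituent on the benzyl ring. In a functional assay on KB cells (Homo sapiens) for cytotoxicity, read by MTT assay, with a stated time of 3 days (a higher number here means a weaker inhibitor, a lower number a stronger inhibitor), compound 1 reaches a limit, > 50000 nM, and gives no number. Among the compounds with values here, compound 2 gives 20000 nM in this assay, the only number among the two measured compounds. The remaining value, that of compound 1, is the limit of > 50000 nM in this assay, at which 1 of the 2 values shown sits. Within the data shown here, the one measured step, an at least 2.5-fold lower number from compound 1 to compound 2 (0.39 log units; beyond the scatter), is at least modest. Compound 3 `C=C1c2c(C)nc(OC)c(C#N)c2N=CN1Cc1ccc(C)cc1` differs from compound 2 by methyl in place of chloro on an aromatic carbon. Among the measured compounds shown here, because the only measured step is an at least 2.5-fold lower number from compound 1 to compound 2 (0.39 log units; beyond the scatter), where chloro entered in place of hydrogen, and here methyl replaces that chloro, compound 3 is expected to show a step of a 1.5-fold higher number from compound 2 to compound 3 (0.18 log units; within the scatter), within or just beyond the scatter, with some chance that this assay reports only a limit. Compound 3 is therefore estimated at 30000 nM in this assay, within a range of 12000 nM to 80000 nM.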

Compound 3, half-maximal inhibitory concentration: 480 nM
Estimate against measurement, compound 3: 63-fold (1.80 log units) above; measured number below the stated range.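

With a 42-fold lower number from compound 2 to compound 3 (1.62 log units; beyond the scatter) in this assay, the 4-methylbenzyl and 4-chlorobenzyl groups prove not to be interchangeable, although each puts a single heavy atom on the same aromatic carbon. Set against the unsubstituted benzyl group, methyl gives an at least 100-fold lower number from compound 1 to compound 3 (2.01 log units; beyond the scatter), a much larger step than chloro gave at the same place, so what happens at this position depends on which group enters and not merely on a group being there. The value of compound 1 is a limit and not a number: the limit of > 50000 nM in this assay, at which 1 of the 3 values shown sits.

The compounds shown leave open whether this strength belongs to methyl alone or would extend to ethyl, methoxy, an amine or a longer chain at this place. They also give no reason why methyl and chloro part so sharply.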